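Swapping 1-phenylethyl for 4-methoxyphenyl on the shared core

The source may hold more compounds than are shown below. What is called first, only, known or untested is meant among the compounds shown, and "the series" means these compounds.

Measured in a physicochemical assay for solubility, read by HPLC, in phosphate buffer, with a stated time of 24 h, at pH 7.4, tested at 100 uM; a higher number here means a more soluble compound, a lower number a less soluble compound:
- compound 1 `C[C@H](Nc1c(NCCCCCC(=O)NO)c(=O)c1=O)c1ccccc1`: 73000000 nM
- compound 2 `CC[C@H](Nc1c(NCCCCCC(=O)NO)c(=O)c1=O)c1ccccc1`: 75000000 nM

Compound 1 and compound 2 lie within the scatter of each other, so the two numbers give compound 1 no meaningful rank. Going by the values given here, the only measured step is a 1.0-fold higher number from compound 1 to compound 2 (0.01 log units; within the scatter). That step adds a methyl in place of hydrogen on a saturated chain carbon and leaves the aromatic ring of the group in place.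

Compound 3 `COc1ccc(Nc2c(NCCCCCC(=O)NO)c(=O)c2=O)cc1` is the next case, and its change is larger: 4-methoxyphenyl in place of 1-phenylethyl on a nitrogen on an aromatic ring. In words, 4-methoxyphenyl stands in place of 1-phenylethyl on a nitrogen on an aromatic ring. Among the compounds with values here, no measured step covers a swap of this kind, so the flat result for compound 2 at 75000000 nM offers only weak guidance. A modest drop in this assay is expected, though with little certainty, and a result within the scatter of compound 1 would not be surprising.

The step expected is a 1.8-fold lower number from compound 1 to compound 3 (0.26 log units; within the scatter). For compound 3 the estimated value is 40000000 nM, with an expected range of 13000000 nM to 85000000 nM.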

Compound 3, solubility: 3300000 nM
The estimate for compound 3 lay 12-fold (1.08 log units) above the measured number; measured number outside the range, below it.
By their numbers in this assay, from the lowest: compound 3; then compounds 1 and 2 (each within the scatter of the next).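

In this assay, the group on a nitrogen on an aromatic ring proves to be a sensitive place in the series: the swap to 4-methoxyphenyl gives a large step (a 22-fold lower number from compound 1 to compound 3 (1.34 log units; beyond the scatter)), whereas the added methyl on the saturated chain carbon stayed within the scatter (a 1.0-fold higher number from compound 1 to compound 2 (0.01 log units; within the scatter)). The leaving and entering groups match in heavy-atom count and each holds one six-membered aromatic ring of carbon only, so that count does not track the step; they differ in the oxygen, the hydrogen-bond acceptor and the defined stereocentre of 1-phenylethyl. Nothing available here assigns the step to any one of these differences.

Going by these compounds alone, the single swap takes away the saturated carbon of 1-phenylethyl and brings in the methoxy group together. A plain phenyl or a 1-(4-methoxyphenyl)ethyl group on the same nitrogen would separate these two changes. Also open, as far as these compounds go, is whether a carboxylic acid or an amine on the aromatic ring of the group would hold the number nearer that of compound 1.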